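Vinyl sulfone series: thienyl exchange on the bromobenzoyl core

The source may report more compounds than this note shows. Statements on the series, on what has been measured and on what is new or still open speak of the compounds shown alone.

Compound 3 `COc1ccccc1/C=C(\C(=O)c1ccc(Br)cc1)S(=O)(=O)c1ccc(C)cc1` gives 1000 nM in a functional assay on DU-145 cells (Homo sapiens) for inhibition, read by trypan blue exclusion, with a stated time of 96 h; on this read-out higher numbers stand for weaker inhibition of growth and lower numbers for stronger inhibition of growth. Compound 2 `CSc1ccc(/C=C(\C(=O)c2ccc(Br)cc2)S(=O)(=O)c2ccc(C)cc2)cc1` gives 1000 nM, and the step of no change at the digits printed from compound 2 to compound 3 (within the scatter) shows no change within the scatter. Both sit at the lowest number among the three measured compounds; compound 1 `Cc1ccc(S(=O)(=O)/C(=C/c2ccc(C)s2)C(=O)c2ccc(Cl)cc2)cc1` gives 50000 nM, a much higher number, beyond the scatter.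

Compound 4 `Cc1ccc(S(=O)(=O)/C(=C/c2ccc(C)s2)C(=O)c2ccc(Br)cc2)cc1` is not yet measured. Among the measured compounds shown here, the change 5-methylthiophen-2-yl in place of 2-methoxyphenyl on a double-bonded chain carbon bound to a double-bonded chain carbon has no directly measured counterpart; the only measured step on this position, from compound 2 to compound 3, exchanges two six-membered aromatic rings and is flat. Compound 4, however, carries the same 5-methylthiophen-2-yl group on the same chain carbon as compound 1, and compound 1 gives 50000 nM, a number far above that of compound 3. That comparison carries the expectation: compound 4 is expected to give a clearly higher number, an estimated step of a 20-fold higher number from compound 3 to compound 4 (1.30 log units; beyond the scatter). The estimate for compound 4 is 20000 nM, with a range of 3000 nM to 100000 nM.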

Compound 4, concentration for 50% growth inhibition: 25000 nM
For compound 4 the middle estimate is 1.3-fold (0.10 log units) below the measured one; the range from low to high includes it.
By their numbers in this assay, from the lowest: compounds 2 and 3 (each within the scatter of the next); then compounds 4 and 1 (each within the scatter of the next).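

In this assay the 5-methylthiophen-2-yl group in place of 2-methoxyphenyl gives a 25-fold higher number from compound 3 to compound 4 (1.40 log units; beyond the scatter) and in place of 4-(methylsulfanyl)phenyl gives a 25-fold higher number from compound 2 to compound 4 (1.40 log units; beyond the scatter) on the same bromo-bearing core, so this position, flat between the two six-membered aromatic rings, is far from flat once the five-membered aromatic ring enters. Bromo in place of chloro on an aromatic carbon gives a 2.0-fold lower number from compound 1 to compound 4 (0.30 log units; within the scatter) and so leaves compound 1 and compound 4 together, which ties their high numbers to the shared 5-methylthiophen-2-yl group in both halogen settings. Nothing measured here accounts for the size of this step.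

As far as these compounds go, whether the high numbers follow the thiophene ring itself or its methyl group stays open, as does where an unsubstituted thiophen-2-yl or a pyridine ring would fall on this chain carbon. From the compounds shown here alone, how a nitrile or a carboxylic acid in place of the halogen would read also stays open.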